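Amide in Place of Acid: Expected Binding of Compound 4

The source may report more compounds than this note shows. Statements on the series, on what has been measured and on what is new or still open speak of the compounds shown alone.

Compound 1, `CCCS(=O)(=O)Nc1ccc(F)c(C(=O)c2n[nH]c3ncc(-c4ccc(C(F)(F)F)cc4)cc23)c1F`: 29%
Compound 2, `CCCS(=O)(=O)Nc1ccc(F)c(C(=O)c2n[nH]c3ncc(-c4ccc(-c5nnn[nH]5)cc4)cc23)c1F`: 0.15%
Compound 3, `CCCS(=O)(=O)Nc1ccc(F)c(C(=O)c2n[nH]c3ncc(-c4ccc(C(=O)O)cc4)cc23)c1F`: 0.1%

Three compounds share one core and differ only in the group on the outer aromatic carbon. In an assay for binding affinity to dual specificity mitogen-activated protein kinase kinase 4 (Homo sapiens), read by KINOMEscan, tested at 100 nM (a lower number here means a stronger effect, a higher number a weaker effect of the compound at the concentration tested), compound 1 gives 29%, whereas compound 2 gives 0.15% and compound 3 gives 0.1%. The two steps away from compound 1 are a number 28.9 percentage points lower from compound 1 to compound 2 (beyond the scatter) and a number 28.9 percentage points lower from compound 1 to compound 3 (beyond the scatter), both beyond the scatter. Between the other two the step is a number 0.1 percentage points lower from compound 2 to compound 3 (within the scatter), within the scatter, so compound 3 holds the lowest number of the three but cannot be set apart from compound 2.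

Compound 4 is `CCCS(=O)(=O)Nc1ccc(F)c(C(=O)c2n[nH]c3ncc(-c4ccc(C(N)=O)cc4)cc23)c1F`. It differs from compound 3 by amino in place of hydroxy on a carbonyl carbon, the carboxy becoming carbamoyl while one hydrogen-bond donor stays. Among the measured compounds shown here, no measured step repeats this exact change. The closest guide is the step from compound 2 to compound 3, which shows that exchanging one small polar group for another at this place left the read-out essentially unchanged. The large steps from compound 1 are less relevant, since they involve trifluoromethyl. Hence a step within the scatter is expected for compound 4, estimated as a number 0.9 percentage points higher from compound 3 to compound 4 (within the scatter). Compound 4 is therefore estimated at 1%, with a range from 0.1% to 8%.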

Compound 4, a percentage reported as activity, at one concentration (the size of the read-out at that concentration, not a potency): 0.15%
The estimate for compound 4 lay 0.9 percentage points above the measured number; measured number inside the range.
By their numbers in this assay, from the lowest: compounds 3, 2 and 4 (each within the scatter of the next); then compound 1.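

Among the compounds shown here, replacing hydroxy with amino on the carbonyl carbon, a change not tested by the earlier compounds, gives a number 0.1 percentage points higher from compound 3 to compound 4 (within the scatter) in this assay, so the carboxy group can become carbamoyl without a readable change in this read-out. Carbamoyl also matches the other group that had stood level with carboxy, with no change at the digits printed from compound 2 to compound 4 (within the scatter), and it differs clearly from trifluoromethyl, with a number 28.9 percentage points lower from compound 1 to compound 4 (beyond the scatter), so three different groups at this place now stand apart from trifluoromethyl, the only one of the four that goes against the low read-out. Nothing available here accounts for why these three groups give such similar numbers.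

The compounds shown leave open where the line falls between these groups and trifluoromethyl: a methyl ester, a nitrile or an N-methylcarbamoyl group at the same place could stay with the three or move toward compound 1. Since the read-out comes from one concentration, it also leaves open whether compound 2, compound 3 and compound 4 would still be indistinguishable in the size of their effect at other concentrations.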